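A few compounds are considered here, and "the series" means these few. Any claim that something is new, unique, unknown or untested is made for them only; others in the source may bear on it.

Working notes on the series, read in a functional assay on A549 cells (Homo sapiens) for antiproliferative activity, read by MTT assay, with a stated time of 48 h; a higher number here means a weaker inhibitor, a lower number a stronger inhibitor. Compound 1 `CCN(CC)CCCn1c(N)c(-c2nc3ccccc3n2C)c2nc(C#N)c(C#N)nc21` gives 10700 nM. Compound 2 `CN(C)CCn1c(N)c(-c2nc3cc(Cl)ccc3[nH]2)c2nc(C#N)c(C#N)nc21` stands at > 50000 nM, which is a limit of the assay and not a number.

Compound 3 `CCN(CC)CCCn1c(N)c(-c2nc3cc(Cl)ccc3[nH]2)c2nc(C#N)c(C#N)nc21` is the next case to read against compound 2: (diethylamino)methyl in place of dimethylamino on a saturated chain carbon, two bonds along the chain from an aromatic nitrogen. In words, (diethylamino)methyl stands in place of dimethylamino on a saturated chain carbon, two bonds along the chain from an aromatic nitrogen. The same difference reads as 2-(dimethylamino)ethyl to 3-(diethylamino)propyl.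

For the measured compounds named here, no measured pair isolates this change. Going by the values given here, compound 1 is the only measured compound with the 3-(diethylamino)propyl chain, and it also differs from compound 3 elsewhere on the shared core, so it is only a loose guide. Resting on compound 1 at 10700 nM, a moderate step toward stronger inhibition in this assay is expected. A reading that stays at the limit remains possible. The expected change is an at least 2.5-fold lower number from compound 2 to compound 3 (0.39 log units; beyond the scatter). For compound 3 the estimated value is 20000 nM, with an expected range of 6000 nM to 50000 nM.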

Compound 3, half-maximal inhibitory concentration: > 50000 nM
Compound 3: a limit, no number (the forecaster's own chance of this, stated with the estimate: 30%); middle value at least 2.5-fold (0.39 log units) away from the limit.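

With the 3-(diethylamino)propyl chain held, 5-chloro-1H-benzimidazol-2-yl in place of 1-methyl-1H-benzimidazol-2-yl on an aromatic carbon gives an at least 4.6-fold higher number from compound 1 to compound 3 (0.66 log units; beyond the scatter) in this assay, so the group on that carbon matters in this series, and the step is a lower bound on its size. The change on the chain, from 2-(dimethylamino)ethyl to 3-(diethylamino)propyl, cannot be read, because compound 2 and compound 3 each stand at a limit and not at a number: the limit of > 50000 nM in this assay, at which 2 of the 3 values shown sit. For the compounds shown here, with 5-chloro-1H-benzimidazol-2-yl in place, the 3-(diethylamino)propyl chain therefore shows no measurable gain, and the only number still belongs to compound 1.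

The step from compound 1 changes the chlorine and the methyl on nitrogen together, so the compounds shown do not tell which of the two goes with the weaker reading; a plain 1H-benzimidazol-2-yl group on the same chain would separate them. From the compounds shown here alone, whether the chain matters at all also stays open, and a 2-(dimethylamino)ethyl chain on the 1-methyl-1H-benzimidazol-2-yl core, or a longer chain ending in a morpholine, would bear on that.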